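This account rests on a few compounds, and the source may have more. Where it says the series, first, only, none or still open, it means among the compounds named here.

Compound 1 `Clc1ccc(Cn2cc(C3CC(c4ccncc4)=NO3)c3ccccc32)cc1` was tested in a functional assay on MDA-MB-231 cells (Homo sapiens) for inhibition, read by MTT assay, with a stated time of 48 h (a lower number here means a stronger inhibitor, a higher number a weaker inhibitor), where compound 1 gives 13700 nM. Compound 2 `COc1ccc2c(c1)c(C1CC(c3ccncc3)=NO1)cn2Cc1ccc(Cl)cc1` carries one more group than compound 1; in this assay compound 2 gives 26000 nM, so compound 1 has the lowest of the two numbers, with compound 2 nearest. The step of a 1.9-fold higher number from compound 1 to compound 2 (0.28 log units; within the scatter) adds a methoxy in place of hydrogen on an aromatic carbon of the shared core. Compound 3 `COc1ccc2c(C3CC(c4ccncc4)=NO3)cn(Cc3ccc(Cl)cc3)c2c1` differs from compound 1 by methoxy in place of hydrogen on an aromatic carbon, the same kind of change set on another aromatic carbon of the shared core. Among the measured compounds shown here, only that one step can guide the expectation, and it stays within the scatter, so no shift beyond the scatter is expected here either, with a slight lean toward a higher number because of a 1.9-fold higher number from compound 1 to compound 2 (0.28 log units; within the scatter). Compound 3 is therefore estimated at 20000 nM, between 9000 nM and 45000 nM. That estimate means an expected step of a 1.5-fold higher number from compound 1 to compound 3 (0.16 log units; within the scatter).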

Compound 3, half-maximal inhibitory concentration: > 100000 nM
Compound 3 gave a limit, no number; the forecaster's own chance of this, stated with the estimate: 10%; middle value at least 5.0-fold (0.69 log units) away from the limit.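

On this aromatic carbon, methoxy in place of hydrogen weakens the compound clearly in this assay: the step is an at least 7.2-fold higher number from compound 1 to compound 3 (0.86 log units; beyond the scatter). The same change on another aromatic carbon of the shared core gave only a 1.9-fold higher number from compound 1 to compound 2 (0.28 log units; within the scatter), so in these three compounds the place of the methoxy matters, not just its presence. The reading for compound 3 is a limit and not a number: the limit of > 100000 nM in this assay, at which 1 of the 3 values shown sits.

On these data alone, the full size of this step stays open, and so does the question of whether only methoxy has this effect here or any group on this carbon would. A fluorine, a hydroxyl, an amine or a longer chain such as ethoxy at the same place would help to separate these cases.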